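A few compounds are considered here, and "the series" means these few. Any claim that something is new, unique, unknown or untested is made for them only; others in the source may bear on it.

Compound 1, `C/C(=N\NC(=O)COc1cccc2ccccc12)c1ccc(C#N)cc1Br`, gives 20 ug/mL in an ADME assay on HEL cells (Homo sapiens) for cytotoxicity; a lower number here means that less compound is tolerated, a higher number that more compound is tolerated.
Compound 2, `O=C(COc1cccc2ccccc12)N/N=C/c1cccc(O)c1`, gives 100 ug/mL in this assay.
Compound 3, `O=C(COc1cccc2ccccc12)N/N=C/c1ccc(Br)cc1`, shows only a limit of > 100 ug/mL in this assay.

Compound 1 holds the lower of the two numbers; compound 2 sits higher, beyond the scatter. Among the measured compounds shown here, the only measured step, a number no lower from compound 2 to compound 3 (the limit leaves the size open), changes a different position and ends at a limit, so its size is open; it offers no direct guide to the change now considered. Compound 4, `C/C(=N\NC(=O)COc1cccc2ccccc12)c1ccccc1Br`, differs from compound 1 by hydrogen in place of cyano on an aromatic carbon. For the measured compounds named here, since no measured step touches this position, compound 4 is expected to move by a 2.0-fold higher number from compound 1 to compound 4 (0.30 log units; within the scatter), a modest rise. Compound 4 is therefore estimated at 40 ug/mL, between 15 ug/mL and 100 ug/mL, with some chance of reaching (the limit of > 100 ug/mL in this assay, at which 1 of the 3 values shown sits).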

Compound 4, minimum cytotoxic concentration in the HEL assay: 20 ug/mL
For compound 4 the middle estimate is 2.0-fold (0.30 log units) above the measured one; measured number inside the range.
By their numbers in the HEL assay, from the lowest: compounds 1 and 4 (each within the scatter of the next); then compound 2.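

Among the compounds shown here, in the HEL assay, the first reading at this position, hydrogen in place of cyano para to a large group, gives no change at the digits printed from compound 1 to compound 4 (within the scatter). In a physicochemical assay for lipophilicity, measured as octanol-water partition (a lower number here means a more polar compound, a higher number a more lipophilic compound), compound 1 gives 3.61 and compound 4 gives 4.44, which is a number 0.83 log units higher from compound 1 to compound 4 (beyond the scatter). The same change thus separates the two compounds by partition coefficient but not in the HEL assay. From the compounds shown here alone, whether an amine or a carboxylic acid at this position would move the number in the HEL assay stays open. So does the part played by the bromo group in this series.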